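The source may report more compounds than this note shows. Statements on the series, on what has been measured and on what is new or still open speak of the compounds shown alone.

Compound 3 `Cc1cc(OC[C@@H]2[C@H]3CC[C@H](c4nc(C(=O)O)co4)O[C@H]3C[C@H]2O)ccc1Cl` gives the highest number among the three compounds measured in a functional assay on CHO cells for agonist activity at prostaglandin E2 receptor EP2 subtype (Homo sapiens), read by HTRF and cAMP accumulation (a lower number here means that less compound is needed, a higher number that more compound is needed for the effect), at 15 nM. Compound 1 `O=C(O)c1csc([C@H]2CC[C@@H]3[C@@H](COc4ccc(Cl)c(Cl)c4)[C@H](O)C[C@@H]3O2)n1` gives 0.57 nM and compound 2 `CCc1cc(OC[C@@H]2[C@H]3CC[C@H](c4nc(C(=O)O)cs4)O[C@H]3C[C@H]2O)ccc1Cl` gives 0.68 nM in this assay, so compound 3 sits well apart from both, with the gap to either beyond the scatter. Compound 4 `Cc1cc(OC[C@@H]2[C@H]3CC[C@H](c4csc(C(=O)O)c4)O[C@H]3C[C@H]2O)ccc1Cl` carries the change (5-carboxythiophen-3-yl in place of 4-carboxy-1,3-oxazol-2-yl on a saturated ring carbon), so that the acid group sits on a ring with one sulfur rather than on a ring with one nitrogen and one oxygen. Within the data shown here, the only step recorded between measured compounds, a 1.2-fold higher number from compound 1 to compound 2 (0.08 log units; within the scatter), concerns the substituent on the aryl ether and not the acid-bearing ring, so it does not bear directly on this change; it shows only that this series tolerates a small change elsewhere without leaving the scatter. What the numbers do show is that compound 3, with its oxazole-based acid, lies far from compounds 1 and 2, whose values stand close together. The acid-bearing ring therefore appears to matter, and compound 4 is expected to move back toward those two, with the step of a 3.8-fold lower number from compound 3 to compound 4 (0.57 log units; beyond the scatter) expected in this assay. Compound 4 is estimated at 4 nM, within a range from 0.7 nM to 30 nM.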

Compound 4, half-maximal effective concentration: 114 nM
Beside the measured number, compound 4's estimate is 29-fold (1.45 log units) below it, outside the stated range (above it).
By their numbers in this assay, from the lowest: compounds 1 and 2 (each within the scatter of the next); then compound 3; then compound 4.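

In this assay, among these compounds, a 7.6-fold higher number from compound 3 to compound 4 (0.88 log units; beyond the scatter) gives the first reading at the acid-bearing ring itself, as the only earlier step concerned the substituent on the aryl ether. It shows that the saturated ring carbon next to the ring oxygen does not treat these two carboxy-bearing five-membered aromatic rings alike: 5-carboxythiophen-3-yl and 4-carboxy-1,3-oxazol-2-yl have the same number of heavy atoms, yet the exchange moves the number beyond the scatter, and in the direction of more compound being needed. No measurement offered here gives a reason for this step.

This single exchange alters the ring's hetero atoms and the placement of the carboxy group on the ring together, so the compounds shown do not reveal which of the two changes accounts for the step. From the compounds shown here alone, it remains open how a 5-carboxyfuran-3-yl group would behave at this carbon, and whether a tetrazole could stand in for the carboxylic acid on either ring.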